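The source may report more compounds than this note shows. Statements on the series, on what has been measured and on what is new or still open speak of the compounds shown alone.

Measured compounds:
compound 1 `CC(/C=C/C1=CCCCC1(C)C)=C\C=C\C(C)=C\COC(=O)c1cccc(O)c1O`; compound 2 `COc1cc(O)c(C(=O)OC/C=C(C)/C=C/C=C(C)/C=C/C2=CCCCC2(C)C)c(O)c1`; compound 3 `CC(/C=C/C1=CCCCC1(C)C)=C\C=C\C(C)=C\COC(=O)c1ccccc1O`.

In a toxicity assay on cells (Fibroblast, Homo sapiens) for cytotoxicity (a higher number here means a weaker inhibitor, a lower number a stronger inhibitor), compound 1 returns only a limit, < 10000 nM, the floor of this measurement (the limit of < 10000 nM in this assay, at which 1 of the 3 values shown sits). Compound 2 gives 14000 nM. Within the data shown here, compound 3 gives 150000 nM, the highest of the two numbers known, set apart from its nearest neighbour by an 11-fold higher number from compound 2 to compound 3 (1.03 log units; beyond the scatter). Compound 4 `COc1cccc(C(=O)OC/C=C(C)/C=C/C=C(C)/C=C/C2=CCCCC2(C)C)c1O` adds a substituent to the ring of compound 3: methoxy in place of hydrogen on an aromatic carbon. Among the measured compounds shown here, two measured steps bear on it, an at least 15-fold higher number from compound 1 to compound 3 (1.17 log units; beyond the scatter) and an 11-fold higher number from compound 2 to compound 3 (1.03 log units; beyond the scatter), each large and beyond the scatter, and each arriving at the less substituted ring of compound 3. Restoring a group on that ring is therefore expected to reverse part of this, a step down beyond the scatter, a 3.8-fold lower number from compound 3 to compound 4 (0.57 log units; beyond the scatter). Compound 4 is estimated at 40000 nM, between 12000 nM and 150000 nM.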

Compound 4, half-maximal inhibitory concentration: 27000 nM
Compound 4: the middle estimate sits 1.5-fold (0.17 log units) above what was measured; measured number inside the range.
By their numbers in this assay, from the lowest: compounds 2 and 4 (each within the scatter of the next); then compound 3. At a limit, below all of these: compound 1.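

Methoxy ortho to a hydroxy group on its own lowers the number on the 2-hydroxyphenyl ring, a modest change (a 5.6-fold lower number from compound 3 to compound 4 (0.74 log units; beyond the scatter)). Compound 4 cannot be told apart from compound 2 (a 1.9-fold higher number from compound 2 to compound 4 (0.29 log units; within the scatter)), although the two carry different ring substitution. Methyl on the oxygen of the hydroxy group at this position raises the number (an at least 2.7-fold higher number from compound 1 to compound 4 (0.43 log units; beyond the scatter)), but this size is only a floor, since compound 1 is a limit: the limit of < 10000 nM in this assay, at which 1 of the 4 values shown sits.

From the compounds shown here alone, whether ethoxy or an amine at this position would behave like methoxy stays open. Going by these compounds, how far compound 1 lies under its limit also stays open.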